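This account rests on a few compounds, and the source may have more. Where it says the series, first, only, none or still open, it means among the compounds named here.

The compounds measured in an assay on PC-12 cells for displacement of a labelled ligand from vesicular acetylcholine transporter (Homo sapiens); a higher number here means a weaker inhibitor, a lower number a stronger inhibitor:

compound 1, `OC1CN(Cc2cccc(Br)c2)CCC1N1CCN(c2ccccc2)CC1`: compound 1 gives 66 nM.
compound 2, `OC1CN(Cc2ccc(Br)cc2)CCC1N1CCN(c2ccccc2)CC1`: compound 2 gives > 100 nM, which is a limit of the assay and not a number.
compound 3, `CCN1CCC(N2CCN(c3ccccc3)CC2)C(O)C1`: compound 3 gives > 1000 nM, which is a limit of the assay and not a number.

Compound 3 thus stands at the limit of > 1000 nM in this assay, at which 1 of the 3 values shown sits, so only a limit is known for it. One further value shown is also only a limit, namely compound 2 at the limit of > 100 nM in this assay, at which 1 of the 3 values shown sits.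

Compound 4, `C=CCN1CCC(N2CCN(c3ccccc3)CC2)C(O)C1`, differs from compound 3 by vinyl in place of methyl on a saturated chain carbon bound to an amine nitrogen in a ring. The measured steps at this place are an at least 15-fold higher number from compound 1 to compound 3 (1.18 log units; beyond the scatter) and a step that the two limits leave unreadable from compound 2 to compound 3, with an at least 1.5-fold higher number from compound 1 to compound 2 (0.18 log units; that floor lies within the scatter) between the two aryl groups. Only the large step from the 3-bromophenyl compound to the methyl compound is readable, and a vinyl adds little to a methyl at this place. Compound 4 is therefore expected to stay near the limit of compound 3, with a step that the limit leaves unreadable from compound 3 to compound 4 expected to lie within the scatter. Compound 4 is estimated at 1500 nM, between 500 nM and 5000 nM.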

Compound 4, half-maximal inhibitory concentration: > 100 nM
Compound 4: a limit, no number; the forecaster's own chance of this, stated with the estimate: 65%; the middle value does not contradict the limit.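

In this assay compound 4 gives > 100 nM, which is a limit of the assay and not a number. Among the compounds shown here, compound 4 rests at the lower of the two limits seen so far: the limit of > 100 nM in this assay, at which 2 of the 4 values shown sit. Its steps to compound 3 and compound 2 cannot be read, so the result does not show whether vinyl differs from methyl at this place, and the only readable step, an at least 1.5-fold higher number from compound 1 to compound 4 (0.18 log units; that floor lies within the scatter), does not establish a loss on going from 3-bromophenyl to vinyl, unlike the large step printed for methyl.

The compounds shown leave open how far the value of compound 4 lies from that of compound 1. They also leave open how a longer chain, or a phenyl without bromine, would read at this place.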